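The compounds below may be only part of what the source reports. "The series", "measured", "known", "first", "only" and "open" are said of these compounds alone.

The measured compounds are:

Compound 1, `Cc1cc(/C=C2\S/C(=N\c3ccccc3)N(C3CCCCC3)C2=O)c(C)n1-c1ccccc1`, which in an ADME assay on L6 cells (Rattus norvegicus) for cytotoxicity, read by microscopy and resazurin assay, with a stated time of 72 h (a higher number here means that more compound is needed for the effect, a lower number that less compound is needed), gives > 200000 nM, a limit of the assay.
Compound 2, `O=C1/C(=C/c2cnn(-c3ccccc3C(F)(F)F)c2)S/C(=N\c2ccccc2)N1C1CCCCC1`, which in this assay gives > 180000 nM, also a limit.
Compound 3, `Cc1cc(/C=C2\S/C(=N\c3ccccc3)N(C)C2=O)c(C)n1-c1ccccc1`, which in this assay gives > 230000 nM, again a limit.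

From compound 1 to compound 3 the change is methyl in place of cyclohexyl on an amide-type nitrogen in a ring. The step that the two limits leave unreadable from compound 1 to compound 3 cannot be read, as the limit of > 200000 nM in this assay, at which 1 of the 3 values shown sits, and the limit of > 230000 nM in this assay, at which 1 of the 3 values shown sits, show. The difference between the core of compound 1 and the core of compound 2 is not broken down here. Compound 4, `CN1C(=O)/C(=C/c2cnn(-c3ccccc3C(F)(F)F)c2)S/C1=N\c1ccccc1`, has not been measured; it differs from compound 2 by methyl in place of cyclohexyl on an amide-type nitrogen in a ring, the same change as from compound 1 to compound 3. Since compound 3 sits at the limit of > 230000 nM in this assay, at which 1 of the 3 values shown sits, after that change, compound 4 is expected to sit at a limit as well, an expected step that the limit leaves unreadable from compound 2 to compound 4 beside the earlier one. Compound 4 is estimated at 250000 nM, between 100000 nM and 600000 nM.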

Compound 4, half-maximal effective concentration: 180000 nM
Compound 4: the middle estimate sits 1.4-fold (0.14 log units) above what was measured, and the stated range covers the measured number.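

In this assay, methyl in place of cyclohexyl on the core of compound 2 gives a number no higher from compound 2 to compound 4 (the limit leaves the size open), and neither this step nor the earlier one on the core of compound 1 can be read for size. Compound 4 gives 180000 nM, a measured number. On the other core, compound 3 gives > 230000 nM, which is a limit of the assay. The change thus ends in a very high concentration on both cores, but this does not show that it has the same size on both, or any size at all.

The compounds shown leave open what a longer chain or an amine on that nitrogen would give in this assay. They also leave open how far compound 1, compound 2 and compound 3 lie past their limits.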